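The source may hold more compounds than are shown below. What is called first, only, known or untested is meant among the compounds shown, and "the series" means these compounds.

Measured so far:
- compound 1, `COc1nc(N)nc2c1c(-c1cc3ccccc3o1)cn2[C@@H]1O[C@H](CO)[C@@H](O)[C@H]1O`: 16700 nM
- compound 2, `C#Cc1cn([C@@H]2O[C@H](CO)[C@@H](O)[C@H]2O)c2ncnc(OC)c12`: 3490 nM
- compound 3, `Nc1nc2c(c(-c3ccccc3)cn2[C@@H]2O[C@H](CO)[C@@H](O)[C@H]2O)c(=O)[nH]1`: > 20000 nM

These three share a sugar-bearing core and differ in the groups on the ring system. In a functional assay on CEM-DNR-bulk cells (Homo sapiens), read by MTT assay, with a stated time of 72 h (a lower number here means a stronger inhibitor, a higher number a weaker inhibitor), compound 2 gives 3490 nM, the lowest of the two numbers shown. Compound 1 gives 16700 nM, a higher number than compound 2 and beyond the scatter. For compound 3 the assay reports only a limit, > 20000 nM; this is a limit, not a number, and it is the limit (the limit of > 20000 nM in this assay, at which 1 of the 3 values shown sits).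

The unmeasured compound 4 is `COc1ncnc2c1c(-c1ccccc1)cn2[C@@H]1O[C@H](CO)[C@@H](O)[C@H]1O`. It differs from compound 2 in one place: phenyl in place of ethynyl on an aromatic carbon. Compound 4 keeps the methoxy-bearing core of compound 2, while compound 3, which carries phenyl on a different core, reaches only a limit. Going from compound 2 to compound 4 a modest weakening is expected, a 1.7-fold higher number from compound 2 to compound 4 (0.24 log units; within the scatter). Compound 4 is therefore estimated at 6000 nM, within a range from 1500 nM to 20000 nM.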

Compound 4, half-maximal inhibitory concentration: > 20000 nM
Compound 4 was reported as a limit (the forecaster's own chance of this, stated with the estimate: 25%); at least 3.3-fold (0.52 log units) between middle value and limit.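

Putting phenyl in place of ethynyl on this aromatic carbon gives an at least 5.7-fold higher number from compound 2 to compound 4 (0.75 log units; beyond the scatter) in this assay. Within the data shown here, this is the first comparison here in which only one place changes, so the loss can be tied directly to this swap on the core of compound 2: at this position, ethynyl cannot be exchanged for phenyl without a clear loss of activity. The result for compound 4 is a limit and not a number, so the step gives only the least size of the change: the limit of > 20000 nM in this assay, at which 2 of the 4 values shown sit.

On these data alone, with only ethynyl and phenyl compared on this carbon, it remains open how a methyl, a vinyl or a nitrile would read there on the core of compound 2. As far as these compounds go, it also remains open whether a pyridine or thiophene ring would behave like phenyl.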